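Cyclopropyl to Propyl on a Furan and Thiophene Pair

The source may hold more compounds than are shown below. What is called first, only, known or untested is meant among the compounds shown, and "the series" means these compounds.

Measured compounds:
compound 1 `CC1=C(C(=O)C2CC2)C(c2ccoc2)NC(=O)N1` — 1%
compound 2 `CCCC(=O)C1=C(C)NC(=O)NC1c1ccoc1` — 1%
compound 3 `CC1=C(C(=O)C2CC2)C(c2cccs2)NC(=O)N1` — 1%

In an assay on membranes from CHO cells for displacement of a labelled ligand from adenosine receptor A1 (Homo sapiens), read by scintillation counting, with a stated time of 60 min, tested at 1 uM (a lower number here means less inhibition, a higher number more inhibition at the concentration tested (going by the name of the read-out)), compound 1 gives 1%. Compound 2, which carries propyl in place of cyclopropyl on a carbonyl carbon, gives 1% in this assay, so that no change at the digits printed from compound 1 to compound 2 (within the scatter). Compound 3 differs from compound 1 by thiophen-2-yl in place of furan-3-yl on a saturated ring carbon, and in this assay compound 3 gives 1%; no change at the digits printed from compound 1 to compound 3 (within the scatter).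

Compound 4 `CCCC(=O)C1=C(C)NC(=O)NC1c1cccs1` is not yet measured. It stands to compound 3 as compound 2 stands to compound 1: the change is propyl in place of cyclopropyl on a carbonyl carbon, the same change as before, since the place is described in identical words. The earlier step, no change at the digits printed from compound 1 to compound 2 (within the scatter), was flat. Compound 4 is therefore expected to show no change at the digits printed from compound 3 to compound 4 (within the scatter). This expectation rests on that flat step and on the value of compound 3, 1%. The estimate for compound 4 in this assay is 1%, expected between -8% and 10%.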

Compound 4, a percentage reported as inhibition, at one concentration (the size of the read-out at that concentration, not a potency): 2%
Compound 4: the middle estimate sits 1 percentage points below what was measured; measured number inside the range.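

In this assay, propyl in place of cyclopropyl gives a number 1 percentage points higher from compound 3 to compound 4 (within the scatter), and thiophen-2-yl in place of furan-3-yl gives a number 1 percentage points higher from compound 2 to compound 4 (within the scatter), and the propyl change reads alike on both cores: the same change on two cores in this assay, no change at the digits printed (within the scatter) from compound 1 to compound 2 and a number 1 percentage points higher (within the scatter) from compound 3 to compound 4, 1 percentage points apart, within the scatter of two such steps. The thiophen-2-yl change also reads alike on both cores: the same change on two cores in this assay, no change at the digits printed (within the scatter) from compound 1 to compound 3 and a number 1 percentage points higher (within the scatter) from compound 2 to compound 4, 1 percentage points apart, within the scatter of two such steps. Among the compounds shown here, this shows only that two flat steps stay flat on a second core, not that a change which moved the number beyond the scatter would carry over in the same way.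

The compounds shown leave open how a longer chain on the carbonyl carbon would read in this assay. They also leave open what an amine or a carboxylic acid at that place would give.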